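Swapping the lactam substituent on compound 2

This account rests on a few compounds, and the source may have more. Where it says the series, first, only, none or still open, it means among the compounds named here.

Three compounds share a core and were tested in an ADME assay on microsomes from liver (Homo sapiens) for metabolic stability; a lower number here means that the compound disappears faster, a higher number that the compound lasts longer. Compound 1 `CCn1ncc2c(F)cc(-c3ccc(C(CC)(CC)c4nnc(C)[nH]4)c(=O)[nH]3)cc21` gives a value that is a limit of the assay, > 3 h. Compound 2 `CC(C)C(c1ccc(-c2ccc3cccc(F)c3c2)[nH]c1=O)N1CCCCC1=O` gives 0.183 h, while compound 3 `CCC(CC)(c1nnc[nH]1)c1ccc(-c2ccc3cccc(F)c3c2)[nH]c1=O` gives 1.19 h. Among the two numbers recorded, compound 2 stands lowest, with compound 3 the nearest and its number clearly higher, beyond the usual scatter. Compound 4 `CC(C)C(/C=C1/CCNC1=O)c1ccc(-c2ccc3cccc(F)c3c2)[nH]c1=O` has not yet been measured in this assay. It differs from compound 2 in one place: a group of 7 heavy atoms (5 carbon, 1 nitrogen, 1 oxygen; one five-membered non-aromatic ring with 1 hetero atom) in place of a group of 7 heavy atoms (5 carbon, 1 nitrogen, 1 oxygen; one six-membered non-aromatic ring with 1 hetero atom), on a saturated chain carbon bound to an aromatic carbon and a saturated chain carbon. Among the compounds with values here, no measured pair of compounds differs by such a change, so the size of the step can only be guessed. A modest rise in this assay is expected, not far beyond the scatter, and the estimated step is a 1.6-fold higher number from compound 2 to compound 4 (0.21 log units; within the scatter). For compound 4 the expected half-life is 0.3 h, with a likely range from 0.1 h to 0.9 h, which would still leave it well short of compound 3.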

Compound 4, half-life: 0.987 h
For compound 4 the middle estimate is 3.3-fold (0.52 log units) below the measured one; measured number outside the range, above it.
By their numbers in this assay, from the lowest: compound 2; then compounds 4 and 3 (each within the scatter of the next). At a limit, above all of these: compound 1.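

In this assay, replacing the 2-oxopiperidin-1-yl group on this saturated chain carbon gives a 5.4-fold higher number from compound 2 to compound 4 (0.73 log units; beyond the scatter), the first measured sign that the half-life responds to a change at this position. The entering and leaving groups have the same heavy-atom count and composition, so the step comes without any change in those counts. They still differ in ring size, in double bonds outside aromatic rings and in hydrogen-bond donors, and nothing measured here separates these differences or accounts for the size of the step.

The compounds shown leave open whether a 2-oxopyrrolidin-1-yl group, with the smaller ring attached through its nitrogen, would give a similar step. They also leave open how an open-chain amide or an amine on this carbon would compare.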